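The compounds below may be only part of what the source reports. "The series", "measured", "known", "first", "only" and "open" are said of these compounds alone.

Values in a functional assay on HepG2 cells (Homo sapiens) for cytotoxicity, with a stated time of 72 h (on this read-out higher numbers stand for an effect only at larger amounts of compound and lower numbers for an effect already at smaller amounts), follow, each one a limit and not a number.

Compound 1 (`C=C[C@@](C)(/C=C/c1ccc(Nc2ccc(OC)cc2)cc1)CCC=C(C)C`) gives > 52000 nM as a limit.
Compound 2 (`C=C[C@@](C)(/C=C/c1ccc(Nc2cc(F)cc(F)c2)cc1)CCC=C(C)C`) gives > 52000 nM as a limit.
Compound 3 (`C=C[C@@](C)(/C=C/c1ccc(Nc2cc(F)c(F)c(F)c2)cc1)CCC=C(C)C`) gives > 52000 nM as a limit.

Compound 1 has no numeric value and stands at the limit of > 52000 nM in this assay, at which 3 of the 3 values shown sit, in this series.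

Compound 4 (`C=C[C@@](C)(/C=C/c1ccc(Nc2ccc(C(F)(F)F)cc2)cc1)CCC=C(C)C`) has trifluoromethyl in place of methoxy on an aromatic carbon, para to a large group (trifluoromethyl in place of methoxy on an aromatic carbon). The nearest measured changes are a step that the two limits leave unreadable from compound 1 to compound 2 and a step that the two limits leave unreadable from compound 1 to compound 3, so neither gives a size to carry over. No step beyond the scatter is therefore expected in this assay on present evidence. The estimated step is a number no higher from compound 1 to compound 4 (the limit leaves the size open) in size. The estimate for compound 4 is 52000 nM, with an expected range from 28000 nM to 70000 nM in this read-out.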

Compound 4, half-maximal effective concentration: > 52000 nM
Compound 4 was reported as a limit; the forecaster's own chance of this, stated with the estimate: 80%; the middle value sits exactly at the limit.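

No step can be read between compound 1 and compound 4, since both results are limits and not numbers: the limit of > 52000 nM in this assay, at which 4 of the 4 values shown sit.

The compounds shown leave open what numeric value any of them would give, and whether their substituents differ at all in this assay.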